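Phenyl to Thiophen-2-yl, Tried on a Second Core

The source may hold more compounds than are shown below. What is called first, only, known or untested is meant among the compounds shown, and "the series" means these compounds.

Compound 1 `Oc1ccc(-c2cc(-c3ccccc3)cc(-c3ccccc3)n2)cc1` and compound 3 `Oc1cccc(-c2cc(-c3ccccc3)nc(-c3ccccc3)c2)c1` are built from the same atoms joined differently; the difference between the two cores is not broken down here. Among the compounds with values here, in a functional assay on DU-145 cells (Homo sapiens) for cytotoxicity, read by ELISA, with a stated time of 2 days (a higher number here means a weaker inhibitor, a lower number a stronger inhibitor), compound 1 gives 3000 nM, while compound 3 gives 17900 nM, the highest of the three numbers measured so far.

Compound 2 `Oc1ccc(-c2cc(-c3ccccc3)cc(-c3cccs3)n2)cc1` differs from compound 1 in one place, (thiophen-2-yl in place of phenyl on an aromatic carbon). That change brought a 1.2-fold higher number from compound 1 to compound 2 (0.09 log units; within the scatter), so in this assay compound 2 gives 3700 nM.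

Compound 4 `Oc1cccc(-c2cc(-c3ccccc3)nc(-c3cccs3)c2)c1` is not yet measured. It carries the same kind of change on the core of compound 3, (thiophen-2-yl in place of phenyl on an aromatic carbon). The two places are not identical: around compound 1 the change sits meta to a 4-hydroxyphenyl group, around compound 3 meta to a 3-hydroxyphenyl group.

The step from compound 3 to compound 4 is expected to be a 1.1-fold higher number from compound 3 to compound 4 (0.05 log units; within the scatter), because the earlier step of a 1.2-fold higher number from compound 1 to compound 2 (0.09 log units; within the scatter) stayed within the scatter. Compound 4 is therefore estimated at 20000 nM, most likely between 8000 nM and 50000 nM.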

Compound 4, half-maximal inhibitory concentration: 19700 nM
Beside the measured number, compound 4's estimate is 1.0-fold (0.01 log units) above it, within the range that was stated.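

On the second core, putting thiophen-2-yl in place of phenyl gave a 1.1-fold higher number from compound 3 to compound 4 (0.04 log units; within the scatter) in this assay. Set beside the step on the first core, this result agrees with it: the same change on two cores in this assay, a 1.2-fold higher number (0.09 log units; within the scatter) from compound 1 to compound 2 and a 1.1-fold higher number (0.04 log units; within the scatter) from compound 3 to compound 4, 1.1-fold (0.05 log units) apart, within the scatter of two such steps

So on these two cores the swap leaves the number unchanged within the scatter, and the quiet result seen on the first core also held on the second; this does not show that the swap would be as quiet on any other core, and as neither step rises beyond the scatter, the pair shows only that a near-absence of effect carried over, not that a sizeable effect would.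

The compounds shown carry only phenyl or thiophen-2-yl at this place, so it remains open what an amine, a carboxylic acid or a longer alkyl chain there would do to the number. From the compounds shown here alone, it also remains open what would happen with a methoxy group in place of the hydroxyl of the hydroxyphenyl group.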